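Ether chain in place of a branched alkyl on the shared core

The source may hold more compounds than are shown below. What is called first, only, known or untested is meant among the compounds shown, and "the series" means these compounds.

Measured so far:
compound 1 `CC1CCC(Oc2cccc3ccc(N)nc23)C1` gives 823 nM
compound 2 `CCC(C)COc1cccc2ccc(N)nc12` gives 36 nM

Both compounds were tested in an assay on cells with melanin-concentrating hormone receptor 1 (Homo sapiens) as the target, read by radioligand binding; on this read-out higher numbers stand for weaker inhibition and lower numbers for stronger inhibition. Of the two numbers, compound 2 stands lowest; its nearest neighbour is compound 1, and the step of a 23-fold lower number from compound 1 to compound 2 (1.36 log units; beyond the scatter) went with 2-methylbutyl in place of 3-methylcyclopentyl on an oxygen on an aromatic ring.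

Compound 3 `CCOCC(C)Oc1cccc2ccc(N)nc12` has not yet been measured. It differs from compound 2 by a group of 6 heavy atoms (5 carbon, 1 oxygen; no ring) in place of a group of 5 heavy atoms (5 carbon; no ring), on an oxygen on an aromatic ring.

Within the data shown here, only one step is known, and it concerns a ring being opened, not an oxygen entering a chain, so it bears on this step only loosely; it shows that a change of the group on this oxygen can move the number a great deal. With the bulk kept similar but an oxygen entering, a moderate weakening is expected, a 2.5-fold higher number from compound 2 to compound 3 (0.40 log units; beyond the scatter), so compound 3 is estimated at 90 nM, within 25 nM to 320 nM.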

Compound 3, half-maximal inhibitory concentration: 1070 nM
Compound 3: the middle estimate sits 12-fold (1.08 log units) below what was measured; the whole stated range lies below it.
By their numbers in this assay, from the lowest: compound 2; then compounds 1 and 3 (each within the scatter of the next).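

Replacing 2-methylbutyl with a group that holds one hydrogen-bond acceptor, where the group it replaces holds none, came with a 30-fold higher number from compound 2 to compound 3 (1.47 log units; beyond the scatter), so a chain containing an oxygen can cost as much at this position as the ring of compound 1 does. The step of a 1.3-fold higher number from compound 1 to compound 3 (0.11 log units; within the scatter) shows that an open chain on this oxygen is not enough on its own to give the low number of compound 2, as compound 3 has no ring and still lands within the scatter of compound 1. Nothing measured here explains the large loss.

The compounds shown leave open whether the loss follows the oxygen atom itself or the different arrangement of the chain around it. On these data alone, how an amine or a longer all-carbon chain on this oxygen would compare with 2-methylbutyl also remains open.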